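The source may hold more compounds than are shown below. What is called first, only, known or untested is meant among the compounds shown, and "the series" means these compounds.

Compound 1 `CCCCN(C(=O)c1ccc(C(F)(F)F)cc1)c1nnc(-c2cccc3[nH]ccc23)s1` is the reference point of the series. In an ADME assay on microsomes from liver (Mus musculus) for metabolic stability, read by LC-MS, tested at 0.5 uM (on this read-out higher numbers stand for fast clearance and lower numbers for slow clearance), compound 1 gives 63 uL/min, the lowest of the two numbers in hand; the nearest is compound 2 `CCCCN(C(=O)c1ccc(C(F)(F)F)cc1)c1nnc(-c2ccc(CO)cc2)s1`, which in this assay gives 712 uL/min. Among the compounds with values here, the only measured step is an 11-fold higher number from compound 1 to compound 2 (1.05 log units; beyond the scatter), a swap of the aryl group on an aromatic carbon. Within the data shown here, compound 3 `CCCCN(C(=O)c1ccc(C(F)(F)F)cc1)c1nnc(-c2cccc3c2ccn3CCC(=O)O)s1` differs from compound 1 by 2-carboxyethyl in place of hydrogen on an aromatic nitrogen; the change sits on an aromatic nitrogen of the fused ring system, a place that no measured step touches. The step from compound 1 to compound 2 therefore gives no direct guide, and the expectation rests on compound 1 alone. The estimate for compound 3 is a 1.1-fold lower number from compound 1 to compound 3 (0.06 log units; within the scatter), with no step beyond the scatter expected in either direction, and a wide range. The expected value for compound 3 in this assay is 55 uL/min (range 15 uL/min to 200 uL/min).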

Compound 3, intrinsic clearance in a liver preparation (reported as CLH), per the amount of preparation that the assay uses: 91.2 uL/min
Compound 3: middle estimate off by 1.7-fold (0.22 log units), on the low side; measured number inside the range.
By their numbers in this assay, from the lowest: compounds 1 and 3 (each within the scatter of the next); then compound 2.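

On the aromatic nitrogen of the five-membered aromatic ring, part of the fused system, 2-carboxyethyl in place of hydrogen gives a 1.4-fold higher number from compound 1 to compound 3 (0.16 log units; within the scatter) in this assay and so leaves the number within the scatter of compound 1. Within the data shown here, this is the first measured change at this position, and it shows that the nitrogen can carry this chain without a step beyond the scatter, whereas the aryl swap on the aromatic carbon gives an 11-fold higher number from compound 1 to compound 2 (1.05 log units; beyond the scatter) in the same assay. No measured evidence bears on the reason for this result.

One chain cannot show whether the carboxylic acid end or the carbon chain sets the number. A longer chain, an amine or an ester on the same nitrogen remains an open case.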